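From 2-Hydroxyethyl to 3-Hydroxypropyl on Compound 3

This account rests on a few compounds, and the source may have more. Where it says the series, first, only, none or still open, it means among the compounds named here.

Compound 1 `O=C(Nc1ccc(Cl)cc1)c1c(NO)cc(-c2ccccc2)oc1=O` reads > 20000 nM in an ADME assay on Huh-7 cells (Homo sapiens) for cytotoxicity, read by a luciferase reporter and WST assay, with a stated time of 3 days (on this read-out higher numbers stand for lower toxicity in this test and lower numbers for higher toxicity in this test), which is a limit. Compound 2 `CCNC(=O)c1c(NO)cc(-c2ccccc2)oc1=O` reads > 20000 nM, again a limit. Compound 3 `O=C(NCCO)c1c(NO)cc(-c2ccccc2)oc1=O` reads > 20000 nM, likewise a limit. Compound 3 therefore gives no number and stands with the other two at the limit of > 20000 nM in this assay, at which 3 of the 3 values shown sit. Compound 4 `O=C(NCCCO)c1c(NO)cc(-c2ccccc2)oc1=O` follows through (hydroxymethyl in place of hydroxy on a saturated chain carbon, two bonds along the chain from an amide-type nitrogen), a change from 2-hydroxyethyl to 3-hydroxypropyl. The closest measured change is a step that the two limits leave unreadable from compound 2 to compound 3, and the two others are a step that the two limits leave unreadable from compound 1 to compound 2 and a step that the two limits leave unreadable from compound 1 to compound 3. None of these has a readable size, so no step beyond the scatter, in either direction, is expected in this assay. The expected step is a step that the limit leaves unreadable from compound 3 to compound 4. Compound 4 is estimated at 25000 nM, with an expected range of 12000 nM to 40000 nM.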

Compound 4, half-maximal cytotoxic concentration: > 20000 nM
Compound 4 ended at the assay's limit (the forecaster's own chance of this, stated with the estimate: 85%); the middle value is on the limit's open side.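

Among these compounds, compound 4 joins compound 1, compound 2 and compound 3 at a limit in this assay, so no step among them can be read: the limit of > 20000 nM in this assay, at which 4 of the 4 values shown sit. The compounds shown leave open what actual number any of the four would give, and whether changing the group on the amide-type nitrogen shifts that number at all.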